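Adding a chloro group to compound 2

The source may hold more compounds than are shown below. What is called first, only, known or untested is meant among the compounds shown, and "the series" means these compounds.

- compound 1 `Cc1ccc(NC(=O)/C=C/c2ccccc2)c(C(N)=O)c1` gives 3480 nM
- compound 2 `NC(=O)c1cc(I)ccc1NC(=O)/C=C/c1ccccc1` gives 450 nM

In a functional assay on MCF7 cells (Homo sapiens) for inhibition, read by sulforhodamine B assay, with a stated time of 48 h (a higher number here means a weaker inhibitor of growth, a lower number a stronger inhibitor of growth), compound 2 has the lower of the two numbers, making it the stronger inhibitor so far. Compound 3 `NC(=O)c1cc(I)ccc1NC(=O)/C=C/c1ccccc1Cl` keeps the iodo and changes another place: chloro in place of hydrogen on an aromatic carbon. Among the measured compounds shown here, the only measured step is a 7.7-fold lower number from compound 1 to compound 2 (0.89 log units; beyond the scatter), with iodo in place of methyl. For the measured compounds named here, it shows how far one swap can move the number, but no measured step tests this new change, so no clear direction is expected. The expected result is a 1.1-fold lower number from compound 2 to compound 3 (0.05 log units; within the scatter) (an estimate, with wide uncertainty). Compound 3 is estimated at 400 nM (range 130 nM to 1300 nM).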

Compound 3, concentration for 50% growth inhibition: 401 nM
For compound 3 the middle estimate is 1.0-fold (0.00 log units) below the measured one; low and high end bracket the measured number.
By their numbers in this assay, from the lowest: compounds 3 and 2 (each within the scatter of the next); then compound 1.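

Replacing phenyl with 2-chlorophenyl gives a 1.1-fold lower number from compound 2 to compound 3 (0.05 log units; within the scatter) in this assay and so leaves the number essentially unchanged. The earlier step showed that a swap at the iodo position can move the number; this one shows that an aromatic carbon ortho to a large group, in a different part of the molecule, can carry a chloro with no change beyond the scatter. Nothing available explains this result.

On these data alone, it remains open whether an amine or a methoxy group on this carbon would behave like chloro. As far as these compounds go, it is also open whether chloro on another carbon of this ring would do the same.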